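Shortening the 2-cyclohexylethoxy chain of compound 3

The compounds below may be only part of what the source reports. "The series", "measured", "known", "first", "only" and "open" are said of these compounds alone.

- Compound 1 `CC(C)CCCOc1cccc(O)c1C(=O)/C=C/c1ccc(O)cc1`: 3600 nM
- Compound 2 `CC(C)=CCOc1cccc(O)c1C(=O)/C=C/c1ccc(O)cc1`: > 30000 nM (a limit)
- Compound 3 `O=C(/C=C/c1ccc(O)cc1)c1c(O)cccc1OCCC1CCCCC1`: > 30000 nM (a limit)

All three entries come from a functional assay on PC-3 cells (Homo sapiens) for antiproliferative activity, read by sulforhodamine B assay; on this read-out higher numbers stand for weaker inhibition of growth and lower numbers for stronger inhibition of growth. Compound 3 has no number in this assay, and its > 30000 nM is a limit of the assay. That places compound 3 at the limit of > 30000 nM in this assay, at which 2 of the 3 values shown sit.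

Compound 4 `O=C(/C=C/c1ccc(O)cc1)c1c(O)cccc1OCC1CCCCC1` changes one group of compound 3: cyclohexyl in place of cyclohexylmethyl on a saturated chain carbon bound to an oxygen on an aromatic ring. The 2-cyclohexylethoxy chain becomes cyclohexylmethoxy.

Among the measured compounds shown here, two measured steps bear on this part of the molecule, and both lie beyond the scatter. One is an at least 8.3-fold higher number from compound 1 to compound 3 (0.92 log units; beyond the scatter), with cyclohexyl in place of isobutyl. The other is an at least 8.3-fold higher number from compound 1 to compound 2 (0.92 log units; beyond the scatter), with 2-methylprop-1-en-1-yl in place of isopentyl. For the measured compounds named here, the step that the two limits leave unreadable from compound 2 to compound 3 cannot be sized, and no measured step shortens a chain carrying cyclohexyl.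

Among these compounds, only compound 1 gives a number, 3600 nM. Compound 4 keeps the cyclohexyl group of compound 3, so it is expected to remain weak, and the assay may again report only a limit. The expected outcome is no step beyond the scatter in this assay, with the estimated step being a number no higher from compound 3 to compound 4 (the limit leaves the size open). For compound 4 the estimated value is 30000 nM, with an expected range from 10000 nM to 60000 nM.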

Compound 4, concentration for 50% growth inhibition: > 30000 nM
Compound 4 ended at the assay's limit; the forecaster's own chance of this, stated with the estimate: 60%; the middle value lies on the limit itself.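

Shortening the chain by one carbon, from 2-cyclohexylethoxy to cyclohexylmethoxy, does not bring a cyclohexyl compound back to a measurable value, so neither chain length shown for this ring gives a number. In this assay, putting cyclohexyl in place of the isopentyl group of compound 1 gives an at least 8.3-fold higher number from compound 1 to compound 4 (0.92 log units; beyond the scatter), which adds a second cyclohexyl compound that lies beyond the scatter from compound 1. The steps from compound 3 to compound 4 and from compound 2 to compound 4 cannot be read, and compound 4 has a limit rather than a number, which leaves compound 1 as the only one of the four with a number: the limit of > 30000 nM in this assay, at which 3 of the 4 values shown sit.

From the compounds shown here alone, how far compounds 2, 3 and 4 lie past that limit, and whether they differ from one another, stays open. Also open, going by these compounds, is whether a longer chain carrying cyclohexyl, or a phenyl ring or an amine in place of cyclohexyl, would give a number in this assay.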